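From a Furanylmethyl Amine to a Phenylethyl Amine

A few compounds are considered here, and "the series" means these few. Any claim that something is new, unique, unknown or untested is made for them only; others in the source may bear on it.

Of the compounds shown here, three sharing one core have been measured in an assay on CHO cells for displacement of a labelled ligand from 5-hydroxytryptamine receptor 1D (Homo sapiens); on this read-out lower numbers stand for stronger inhibition and higher numbers for weaker inhibition. Compound 1 `CN(CC1CCN(CCCc2c[nH]c3ccc(-n4cnnc4)cc23)CC1)C(=O)Nc1ccccc1` gives 5.9 nM. Compound 2 `O[C@@H]1Cc2ccccc2[C@H]1NC1CCN(CCCc2c[nH]c3ccc(-n4cnnc4)cc23)CC1` gives 6.6 nM. Compound 3 `c1cc(CNC2CCN(CCCc3c[nH]c4ccc(-n5cnnc5)cc34)CC2)co1` gives 4.5 nM. Among these three numbers compound 3 has the lowest, yet its nearest neighbour compound 1 and its furthest neighbour compound 2 both lie within the scatter of it, so no order among the three can be claimed. Going by the values given here, the only step between measured compounds that differ in a single place is a 1.5-fold lower number from compound 2 to compound 3 (0.17 log units; within the scatter), an exchange of groups on an amine nitrogen that left the number essentially where it was.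

Compound 4 `C[C@H](NCC1CCN(CCCc2c[nH]c3ccc(-n4cnnc4)cc23)CC1)c1ccccc1` has not yet been measured. It differs from compound 3 by ((1-phenylethyl)amino)methyl in place of ((furan-3-yl)methyl)amino on a saturated ring carbon. Among the compounds with values here, no measured pair shows a change of this kind; the one step on record, a 1.5-fold lower number from compound 2 to compound 3 (0.17 log units; within the scatter), concerned a different position and a different pair of groups, so it bears on the present step only indirectly. Because compound 1 gives 5.9 nM and compound 2 gives 6.6 nM while compound 3 gives 4.5 nM, all close together despite quite different appendages, the step to compound 4 is expected to be no larger than the scatter, a 1.3-fold higher number from compound 3 to compound 4 (0.12 log units; within the scatter). Compound 4 is estimated at 6 nM, with a range from 2.5 nM to 15 nM.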

Compound 4, half-maximal inhibitory concentration: 4.4 nM
Estimate against measurement, compound 4: 1.4-fold (0.13 log units) above; the measured number falls inside the stated range.
By their numbers in this assay, from the lowest: compounds 4, 3, 1 and 2 (each within the scatter of the next).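

In this assay, putting ((1-phenylethyl)amino)methyl in place of ((furan-3-yl)methyl)amino on this saturated ring carbon gave a 1.0-fold lower number from compound 3 to compound 4 (0.01 log units; within the scatter) and so left the number within the scatter, even though a six-membered aromatic ring of carbon only and a defined stereocentre entered and the five-membered aromatic ring with its hetero atom left. The comparisons with the other two compounds read the same way, with a 1.5-fold lower number from compound 2 to compound 4 (0.18 log units; within the scatter) against the (2-hydroxy-2,3-dihydro-1H-inden-1-yl)amino group and a 1.3-fold lower number from compound 1 to compound 4 (0.13 log units; within the scatter) against methyl(phenylcarbamoyl)amino on the saturated chain carbon. Across these four compounds, then, none of the four appendages separates from the others in this read-out, and no compound goes against that pattern.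

Nothing available explains why these exchanges leave the number where it is. Still open, going by these compounds, is whether a carboxylic acid or a bare primary amine on this saturated ring carbon would also stay within the scatter, and whether the opposite configuration at the stereocentre of the 1-phenylethyl group would do the same.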